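From a hydroxynaphthyl to a thienyl group on the core

This account rests on a few compounds, and the source may have more. Where it says the series, first, only, none or still open, it means among the compounds named here.

Of the compounds shown here, three sharing one core have been tested in a functional assay on Ehrlich cells (Mus musculus) for cytotoxicity, read by trypan blue exclusion, with a stated time of 2 h; on this read-out higher numbers stand for weaker inhibition and lower numbers for stronger inhibition. Compound 1 `N#CC1=C(N)N(c2ccc(S(N)(=O)=O)cc2)C2=C(CCCC2)C1c1ccccc1` reaches only a limit of the assay, > 100 ug/mL. Compound 2 `N#CC1=C(N)N(c2ccc(S(N)(=O)=O)cc2)C2=C(CCCC2)C1c1ccc([N+](=O)[O-])cc1` likewise reaches only a limit, > 100 ug/mL. Going by the values given here, compound 3 `N#CC1=C(N)N(c2ccc(S(N)(=O)=O)cc2)C2=C(CCCC2)C1c1c(O)ccc2ccccc12` is different: in this assay compound 3 gives 100 ug/mL, the single actual number among the three. The steps of a number no higher from compound 1 to compound 3 (the limit leaves the size open) and a number no higher from compound 2 to compound 3 (the limit leaves the size open) both exchange the group on the saturated ring carbon, yet their size cannot be read because the other values sit at the limit of > 100 ug/mL in this assay, at which 2 of the 3 values shown sit. Compound 4 `N#CC1=C(N)N(c2ccc(S(N)(=O)=O)cc2)C2=C(CCCC2)C1c1cccs1` changes that same position: thiophen-2-yl in place of 2-hydroxynaphthalen-1-yl on a saturated ring carbon. The earlier exchanges at this position give no readable size, and the new group is a smaller ring than the one it replaces, which by itself tells nothing about the outcome. The step of no change at the digits printed from compound 3 to compound 4 (within the scatter) expected for compound 4 is therefore small, in neither direction beyond the scatter. Compound 4 is expected to give about 100 ug/mL, between 40 ug/mL and 250 ug/mL.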

Compound 4, half-maximal inhibitory concentration: > 100 ug/mL
Compound 4: a limit, no number; the forecaster's own chance of this, stated with the estimate: 60%; the middle value lies on the limit itself.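

Replacing 2-hydroxynaphthalen-1-yl with thiophen-2-yl gives a number no lower from compound 3 to compound 4 (the limit leaves the size open) at this position. Compound 3 therefore remains the only one of the four with an actual number in this assay and not a limit, and thiophen-2-yl joins phenyl and 4-nitrophenyl among the groups on this saturated ring carbon that reach only the limit. The steps linking compound 4 to compound 1 and to compound 2 cannot be read, and the size of any change at this position stays hidden: the limit of > 100 ug/mL in this assay, at which 3 of the 4 values shown sit.

As far as these compounds go, whether any group on this carbon can bring the value clearly under that of compound 3 at 100 ug/mL stays open. So does what an amine or a carboxylic acid on the phenyl ring of compound 1 would do in this assay on this core.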